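Methyl to chloro on the benzyl of compound 3

A few compounds are considered here, and "the series" means these few. Any claim that something is new, unique, unknown or untested is made for them only; others in the source may bear on it.

Compound 1 `O=C1Nc2ccc(Br)cc2/C1=N/NC(=S)Nc1ccc(Cl)cc1` gives 88000 nM in a functional assay on L1210 cells (Mus musculus), with a stated time of 48 h; a lower number here means a stronger inhibitor, a higher number a weaker inhibitor. Compound 2 `Cc1ccc(NC(=S)N/N=C2\C(=O)Nc3ccc(Br)cc32)cc1` gives 9600 nM in this assay; the change chloro in place of methyl on an aromatic carbon gives a 9.2-fold higher number from compound 2 to compound 1 (0.96 log units; beyond the scatter). Compound 3 `Cc1ccc(CN2C(=O)/C(=N\NC(=S)Nc3ccc(Cl)cc3)c3cc(Cl)ccc32)cc1` gives 9800 nM in this assay; how its core differs from that of compound 2 is not broken down here. Compound 4 `O=C1/C(=N\NC(=S)Nc2ccc(Cl)cc2)c2cc(Cl)ccc2N1Cc1ccc(Cl)cc1` is unmeasured; it differs from compound 3 by chloro in place of methyl on an aromatic carbon, the same change as from compound 2 to compound 1, but on the benzyl of the core rather than on the thiourea aryl. Compound 4 is expected to give a higher number than compound 3, estimated as a 2.2-fold higher number from compound 3 to compound 4 (0.35 log units; beyond the scatter), resting on the step of a 9.2-fold higher number from compound 2 to compound 1 (0.96 log units; beyond the scatter) while allowing for the different position. The estimate for compound 4 in this assay is 22000 nM, within 6000 nM to 80000 nM.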

Compound 4, half-maximal inhibitory concentration: 124000 nM
Compound 4: middle estimate off by 5.6-fold (0.75 log units), on the low side; the measured number lies above the stated range.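

Chloro in place of methyl on the benzyl gives a 13-fold higher number from compound 3 to compound 4 (1.10 log units; beyond the scatter) in this assay, a large step on this core. Set beside the same change on the thiourea aryl of the other core, the two steps agree in direction and in size: the same change on two cores in this assay, a 9.2-fold higher number (0.96 log units; beyond the scatter) from compound 2 to compound 1 and a 13-fold higher number (1.10 log units; beyond the scatter) from compound 3 to compound 4, 1.4-fold (0.14 log units) apart, within the scatter of two such steps. The change therefore carries across these two cores even though it sits on a different aryl in each, but two pairs do not make a rule for other cores and do not show what lies behind the step.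

The compounds shown leave open how other groups at these places, such as fluoro, methoxy or an amine, compare with methyl and chloro. They also leave open whether the step holds with the benzyl absent or replaced by a longer chain.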